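The compounds below may be only part of what the source reports. "The series", "measured", "known", "first", "only" and "open" are said of these compounds alone.

Measured in a functional assay on A-431 cells (Homo sapiens) for inhibition, with a stated time of 72 h; on this read-out lower numbers stand for stronger inhibition and higher numbers for weaker inhibition:
Compound 1 `Oc1c(CN2CCCCC2)ccc2cccnc12`: 9770 nM
Compound 2 `CCN(CC)Cc1cc(Cl)c2cccnc2c1O`: 9330 nM
Compound 3 `Oc1c(CN2CCCC2)cc(Cl)c2cccnc12`: 7410 nM

Compound 3, at 7410 nM, stands level with the other two, as its value lies within the scatter of both. The next compound, compound 4 `CCOCc1cc(CN2CCCC2)c(O)c2ncccc12`, carries ethoxymethyl in place of chloro on an aromatic carbon, para to a hydroxy group: ethoxymethyl in place of chloro on an aromatic carbon. Among the measured compounds shown here, no measured step covers this exchange. For the measured compounds named here, the one step available, a 1.3-fold lower number from compound 2 to compound 3 (0.10 log units; within the scatter), brings pyrrolidin-1-yl in place of diethylamino at a different place, and it stays within the scatter. Compound 1, which carries no chloro group at all, gives 9770 nM, also within the scatter of compound 3. Going by these compounds, nothing measured therefore points to a large move in this assay, although ethoxymethyl itself is untested on the shared core, so the range stays wide. The expected change is a 1.1-fold higher number from compound 3 to compound 4 (0.03 log units; within the scatter), with no step beyond the scatter foreseen in either direction. The estimate for compound 4 is 8000 nM, with an expected range from 3500 nM to 20000 nM.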

Compound 4, half-maximal inhibitory concentration: 33100 nM
Beside the measured number, compound 4's estimate is 4.1-fold (0.62 log units) below it, outside the stated range (above it).
By their numbers in this assay, from the lowest: compounds 3, 2 and 1 (each within the scatter of the next); then compound 4.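

At the aromatic carbon para to a hydroxy group, in this assay, ethoxymethyl in place of chloro gives a 4.5-fold higher number from compound 3 to compound 4 (0.65 log units; beyond the scatter), a modest change but the only step shown that lies beyond the scatter. Among the compounds shown here, this position therefore responds to substitution in a way the one earlier step, which exchanged diethylamino for pyrrolidin-1-yl on the chain carbon, did not show, and here the change runs towards weaker inhibition. Nothing available accounts for this loss.

The compounds shown leave open whether the higher number follows the length of the entering chain or its oxygen, which a butyl chain or a shorter methoxymethyl group at this position would separate. They also leave open how an amine such as aminomethyl or a small group such as fluoro would read there.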